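Swapping the side-chain ring at the assay limit

The source may report more compounds than this note shows. Statements on the series, on what has been measured and on what is new or still open speak of the compounds shown alone.

In a functional assay on HepG2 cells (Homo sapiens) for antiproliferative activity, read by MTT assay, with a stated time of 48 h (a lower number here means a stronger inhibitor, a higher number a weaker inhibitor), compound 1 `CN1CCN(CC(=O)Nc2ccc3ncnc(Nc4ccc(Cl)cc4)c3c2)CC1` gives > 100000 nM as a limit of the assay, not a number. Compound 2 `O=C(CN1CCCC1)Nc1ccc2ncnc(Nc3ccc(Cl)c(C(F)(F)F)c3)c2c1` gives > 100000 nM as a limit too. Compound 2 therefore stands at the limit of > 100000 nM in this assay, at which 2 of the 2 values shown sit, and has no exact number. Compound 3 `CN1CCN(CC(=O)Nc2ccc3ncnc(Nc4ccc(Cl)c(C(F)(F)F)c4)c3c2)CC1` carries 4-methylpiperazin-1-yl in place of pyrrolidin-1-yl on a saturated chain carbon bound to a carbonyl carbon. Among the measured compounds shown here, no measured step shows what this change does in this assay, so no shift in either direction beyond the scatter is expected. The expected step of a number no higher from compound 2 to compound 3 (the limit leaves the size open) is therefore small. For compound 3 the estimated value is 100000 nM, with an expected range from 40000 nM to 250000 nM, and another limit is likely.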

Compound 3, half-maximal inhibitory concentration: 25300 nM
Compound 3: middle estimate off by 4.0-fold (0.60 log units), on the high side; the whole stated range lies above it.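

Among the compounds shown here, the first exact number in this assay shows that the side chain can matter: 4-methylpiperazin-1-yl in place of pyrrolidin-1-yl gives an at least 3.9-fold lower number from compound 2 to compound 3 (0.59 log units; beyond the scatter). With 4-methylpiperazin-1-yl held fixed, the aromatic ring matters too: trifluoromethyl in place of hydrogen on an aromatic carbon gives an at least 3.9-fold lower number from compound 1 to compound 3 (0.59 log units; beyond the scatter). Both steps give only a minimum size because each starting compound stands at a limit: the limit of > 100000 nM in this assay, at which 2 of the 3 values shown sit.

Still open, going by these compounds, is how a morpholine ring or a simple dimethylamino group would read on the same saturated chain carbon. A longer chain carrying 4-methylpiperazin-1-yl also remains untested in the compounds shown here.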